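Replacing the Dichlorophenyl Group with Thiophen-2-yl

A few compounds are considered here, and "the series" means these few. Any claim that something is new, unique, unknown or untested is made for them only; others in the source may bear on it.

Compound 1 `Cn1c(=O)c(=O)n(C2CCCC2)c2nc(N/N=C/c3ccc(S(C)(=O)=O)cc3)ncc21`: 84500 nM
Compound 2 `Cn1c(=O)c(=O)n(C2CCCC2)c2nc(N/N=C/c3cccc(Cl)c3Cl)ncc21`: 39100 nM

In a functional assay on A549 cells (Homo sapiens) for antiproliferative activity, read by MTT assay (on this read-out lower numbers stand for stronger inhibition and higher numbers for weaker inhibition), compound 2 stands lowest of the two, at 39100 nM. Compound 3 `Cn1c(=O)c(=O)n(C2CCCC2)c2nc(N/N=C/c3cccs3)ncc21` has not yet been measured. It departs from compound 2 by one change: thiophen-2-yl in place of 2,3-dichlorophenyl on a carbon with a double bond to nitrogen. Among the compounds with values here, the only measured step at that carbon, a 2.2-fold lower number from compound 1 to compound 2 (0.33 log units; beyond the scatter), is modest, and no thiophen-2-yl compound has a value yet. A similarly modest move towards a higher number is therefore expected in this assay. The estimated change is a 1.3-fold higher number from compound 2 to compound 3 (0.11 log units; within the scatter). Compound 3 is expected at 50000 nM, with an estimated range of 20000 nM to 120000 nM.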

Compound 3, half-maximal inhibitory concentration: > 100000 nM
Compound 3: only a limit was reported; the forecaster's own chance of this, stated with the estimate: 10%; middle value at least 2.0-fold (0.30 log units) away from the limit.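

In this assay compound 3 gives only a limit, > 100000 nM, so its steps are floors. On the carbon with a double bond to nitrogen, thiophen-2-yl in place of 2,3-dichlorophenyl gives an at least 2.5-fold higher number from compound 2 to compound 3 (0.40 log units; beyond the scatter), so this change loses more than the estimate allowed. Against 4-(methylsulfonyl)phenyl the reading is an at least 1.1-fold higher number from compound 1 to compound 3 (0.07 log units; that floor lies within the scatter), so no order between these two groups can be stated.

As far as these compounds go, how far compound 3 lies past its limit stays open: the limit of > 100000 nM in this assay, at which 1 of the 3 values shown sits. Also open, from the compounds shown here alone, is whether an amine or a carboxylic acid on this carbon's ring would give a lower number than compound 2.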